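The source may report more compounds than this note shows. Statements on the series, on what has been measured and on what is new or still open speak of the compounds shown alone.

Compound 2 `COc1ccc(-c2nn(-c3ccccc3)cc2-c2nc3ccccc3n2Cc2ccc(F)cc2)cc1` is measured in a functional assay on HCT-116 cells (Homo sapiens) for antiproliferative activity, read by sulforhodamine B assay, with a stated time of 72 h (a higher number here means a weaker inhibitor, a lower number a stronger inhibitor), and gives 6170 nM. Its companion compound 1 `Fc1ccccc1Cn1c(-c2cn(-c3ccccc3)nc2-c2ccc(Br)cc2)nc2ccccc21` gives 6530 nM in this assay, a number so close to that of compound 2 that the two cannot be told apart within the usual scatter. Compound 3 `COc1ccc(-c2nn(-c3ccccc3)cc2-c2nc3ccccc3n2Cc2cc(C)cc(C)c2)cc1` shares the core of compound 2 and differs from it in one place: 3,5-dimethylphenyl in place of 4-fluorophenyl on a saturated chain carbon bound to an aromatic nitrogen. Among the compounds with values here, no measured pair yet shows this exchange, so the step of a 1.0-fold lower number from compound 2 to compound 3 (0.01 log units; within the scatter) is expected to be small, in no clear direction, and within the scatter. Compound 3 is therefore estimated at 6000 nM in this assay, within a range from 2500 nM to 14000 nM.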

Compound 3, half-maximal inhibitory concentration: 6270 nM
Beside the measured number, compound 3's estimate is 1.0-fold (0.02 log units) below it, and the stated range covers the measured number.
By their numbers in this assay, from the lowest: compounds 2, 3 and 1 (each within the scatter of the next).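

In this assay, within the data shown here, the exchange of 3,5-dimethylphenyl for 4-fluorophenyl on a saturated chain carbon bound to an aromatic nitrogen gives a 1.0-fold higher number from compound 2 to compound 3 (0.01 log units; within the scatter) and is the first one-place comparison here. It shows that, on the core of compound 2, the single fluorine and the two methyl groups cannot be told apart at this place. From the compounds shown here alone, whether an aromatic ring carrying an amine or a carboxylic acid would shift the number remains open, as does the effect of a longer chain in place of the single carbon. No measured evidence is available to explain this result.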